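This account rests on a few compounds, and the source may have more. Where it says the series, first, only, none or still open, it means among the compounds named here.

Measured so far:
compound 1 `Cc1nc2c3ccccc3ccc2c2nc3c(ccc4ccccc43)c(-c3cc([N+](=O)[O-])ccc3N)c12`: 110 ug/mL
compound 2 `Cc1nc2c3ccccc3ccc2c2nc3c(ccc4ccccc43)c(-c3ccccc3)c12`: 188 ug/mL
compound 3 `Cc1nc2c3ccccc3ccc2c2nc3c(ccc4ccccc43)c(-c3nccnc3N)c12`: 134 ug/mL

In a functional assay, with a stated time of 90 s (on this read-out higher numbers stand for weaker inhibition and lower numbers for stronger inhibition), compound 3 stands second highest of the three numbers; its nearest neighbour is compound 1, a 1.2-fold higher number from compound 1 to compound 3 (0.09 log units; within the scatter), and its furthest is compound 2, a 1.4-fold lower number from compound 2 to compound 3 (0.15 log units; within the scatter). Compound 4 `Cc1nc2c3ccccc3ccc2c2nc3c(ccc4ccccc43)c(-c3cccc4ccccc34)c12` differs from compound 3 in one place: naphthalen-1-yl in place of 3-aminopyrazin-2-yl on an aromatic carbon. Among the compounds with values here, the steps that bear on this exchange of the aryl group are a 1.4-fold lower number from compound 2 to compound 3 (0.15 log units; within the scatter) and a 1.7-fold higher number from compound 1 to compound 2 (0.23 log units; within the scatter), both within the scatter, so all three aryl variants sit together. No step beyond the scatter is therefore expected for compound 4; the estimated 1.3-fold higher number from compound 3 to compound 4 (0.10 log units; within the scatter) is small. Compound 4 is estimated at 170 ug/mL, within 85 ug/mL to 340 ug/mL.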

Compound 4, half-maximal inhibitory concentration: 179 ug/mL
Compound 4: the middle estimate sits 1.1-fold (0.02 log units) below what was measured; the range from low to high includes it.
By their numbers in this assay, from the lowest: compounds 1, 3, 4 and 2 (each within the scatter of the next).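

In this assay naphthalen-1-yl at this aromatic carbon, with two carbon-only aromatic rings and no hydrogen-bond donors or acceptors, stays within the scatter of all three earlier aryl groups (a 1.3-fold higher number from compound 3 to compound 4 (0.13 log units; within the scatter)) and (a 1.1-fold lower number from compound 2 to compound 4 (0.02 log units; within the scatter)) and (a 1.6-fold higher number from compound 1 to compound 4 (0.21 log units; within the scatter)). The position therefore accepts a fused aryl group as well as single aromatic rings with or without ring nitrogens or an amino group, with no readable step among the four compounds. Nothing measured explains this flat behaviour.

Open, going by these compounds, is whether a non-aromatic group here, such as morpholine, a carboxylic acid or a longer alkyl chain, would give a step beyond the scatter.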